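From Cyano to Chloro: An Expected Step

A few compounds are considered here, and "the series" means these few. Any claim that something is new, unique, unknown or untested is made for them only; others in the source may bear on it.

Measured so far in a functional assay on T98G cells (Homo sapiens) for inhibition, read by MTT assay, with a stated time of 72 h; on this read-out higher numbers stand for weaker inhibition and lower numbers for stronger inhibition:
compound 1 `CC1(C)CC(NC(=S)Nc2cccc(C#N)c2)c2cc(Br)ccc2O1` gives 9000 nM
compound 2 `CC1(C)CC(NC(=S)Nc2cccc(C#N)c2)c2cc(F)ccc2O1` gives 39000 nM

Of these two numbers, compound 1 holds the lower and so shows the stronger inhibition. Compound 3 `CC1(C)CC(NC(=S)Nc2cccc(Cl)c2)c2cc(Br)ccc2O1` has not yet been measured. It carries chloro in place of cyano on an aromatic carbon and otherwise keeps the core of compound 1. For the measured compounds named here, the only measured step is a 4.3-fold higher number from compound 1 to compound 2 (0.64 log units; beyond the scatter) for fluoro in place of bromo on an aromatic carbon. Going by the values given here, that modest step lies at another place, and no measured pair touches the cyano group, so it indicates a possible size but no direction. A step beyond the scatter is therefore not expected. The estimated step is a 1.1-fold lower number from compound 1 to compound 3 (0.05 log units; within the scatter) and no direction is favoured. For compound 3 the expected value is 8000 nM with an estimated range from 2500 nM to 25000 nM in this assay once it is measured.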

Compound 3, half-maximal inhibitory concentration: 9000 nM
Beside the measured number, compound 3's estimate is 1.1-fold (0.05 log units) below it; measured number inside the range.
By their numbers in this assay, from the lowest: compounds 1 and 3 (each within the scatter of the next); then compound 2.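

In this assay, for the compounds shown here, the first reading at this position, on an aromatic carbon meta to a large group, gives no change at the digits printed from compound 1 to compound 3 (within the scatter). Going by these compounds alone, the earlier compounds showed a change only at the bromo site, so this is the first sign that the 3-cyanophenyl group can give way to 3-chlorophenyl with no change beyond the scatter, even though the nitrile's triple bond and its hydrogen-bond acceptor are gone. Nothing at hand gives a reason for this result.

As far as these compounds go, what an amine or a carboxylic acid would do at this position remains open. Also open, from the compounds shown here alone, is whether the step of a 4.3-fold higher number from compound 1 to compound 2 (0.64 log units; beyond the scatter) would keep its size with chloro in place of cyano.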